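Series notes: a triple bond enters the side chain of compound 3

The source may hold more compounds than are shown below. What is called first, only, known or untested is meant among the compounds shown, and "the series" means these compounds.

Three compounds share one core and differ only in the chain on the saturated ring carbon. Compound 1 `CCOCCC1([C@H](O)/C=C/[C@H]2COC(=O)N2CCSc2nc(C(=O)O)cs2)CCC1` gives 2610 nM in an assay on isolated protein for agonist activity at prostaglandin E2 receptor EP3 subtype (Homo sapiens); a lower number here means that less compound is needed, a higher number that more compound is needed for the effect. Compound 2 `COCCCC1([C@H](O)/C=C/[C@H]2COC(=O)N2CCSc2nc(C(=O)O)cs2)CCC1` gives 25 nM, and compound 3 `CCCCC1([C@H](O)/C=C/[C@H]2COC(=O)N2CCSc2nc(C(=O)O)cs2)CCC1` gives 3.9 nM. The steps are a 100-fold lower number from compound 1 to compound 2 (2.02 log units; beyond the scatter) and a 670-fold lower number from compound 1 to compound 3 (2.83 log units; beyond the scatter), while a 6.4-fold lower number from compound 2 to compound 3 (0.81 log units; beyond the scatter). Compound 3 thus stands lowest of the three, with both its steps beyond the scatter, so it is the most potent compound measured here.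

Compound 4 `CC#CCC1([C@H](O)/C=C/[C@H]2COC(=O)N2CCSc2nc(C(=O)O)cs2)CCC1` is not yet measured. Its difference from compound 3 is prop-1-yn-1-yl in place of propyl on a saturated chain carbon bound to a saturated ring carbon. A triple bond outside aromatic rings enters; donors and acceptors are unchanged.

Within the data shown here, none of the measured steps bears directly on this change: all three concern oxygen in the chain, whereas here the chain stays all-carbon and only its saturation changes. Among the measured compounds shown here, the large swings from compound 1 show the chain is sensitive, but no measured pair shows what a triple bond does. The expectation is therefore a number close to that of compound 3, with a 1.5-fold higher number from compound 3 to compound 4 (0.19 log units; within the scatter) expected to be within or only modestly beyond the scatter. Compound 4 is estimated at 6 nM, with a range from 1.5 nM to 25 nM.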

Compound 4, half-maximal effective concentration: 18 nM
The estimate for compound 4 lay 3.0-fold (0.48 log units) below the measured number; the measured number falls inside the stated range.
By their numbers in this assay, from the lowest: compound 3; then compounds 4 and 2 (each within the scatter of the next); then compound 1.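

In this assay, among these compounds, the step from propyl to prop-1-yn-1-yl (a 4.6-fold higher number from compound 3 to compound 4 (0.66 log units; beyond the scatter)) shows that this position responds to a change in the chain with no oxygen involved, and with donors and acceptors unchanged; the earlier steps all concerned oxygen in the chain. The new chain also stands well apart from the ethoxymethyl chain (a 150-fold lower number from compound 1 to compound 4 (2.16 log units; beyond the scatter)), but it cannot be told apart from the 2-methoxyethyl chain (a 1.4-fold lower number from compound 2 to compound 4 (0.14 log units; within the scatter)), so among these chains only propyl in compound 3 gives a number beyond the scatter of compound 4 on the lower side. Nothing at hand gives a reason for the step from compound 3 to compound 4.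

Open, on these data alone, is whether a prop-1-en-1-yl chain, with a double bond in the same place, would stand with compound 3 or with compound 4, which would show how much of the step follows the degree of saturation. Also open, as far as these compounds go, is whether a longer chain with a triple bond, such as pent-2-yn-1-yl on the saturated ring carbon, would follow the same step as the one from propyl to prop-1-yn-1-yl.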